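Replacing the Methylcarbamoyl Group on Compound 2 with Hydroxy

The source may report more compounds than this note shows. Statements on the series, on what has been measured and on what is new or still open speak of the compounds shown alone.

Of the compounds shown here, two sharing one core have been measured in an assay on isolated protein for inhibition of histone acetyltransferase p300 (Homo sapiens), with a stated time of 60 min; on this read-out higher numbers stand for weaker inhibition and lower numbers for stronger inhibition. Compound 1 `O=C(Nc1ccc2[nH]nnc2c1)[C@H]1CCCN1C(=O)C1(c2cccc(Cl)c2)CCCC1` gives 20 nM in this assay, while compound 2 `CNC(=O)c1ccc(NC(=O)[C@H]2CCCN2C(=O)C2(c3cccc(Cl)c3)CCCC2)cc1` gives 0.794 nM. Compound 2 therefore holds the lowest of the two numbers shown, its nearest neighbour being compound 1; the step of a 25-fold lower number from compound 1 to compound 2 (1.40 log units; beyond the scatter) exchanges the bicyclic group on the amide-type nitrogen for the methylcarbamoyl-substituted phenyl ring.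

Compound 3 `O=C(Nc1ccc(O)cc1)[C@H]1CCCN1C(=O)C1(c2cccc(Cl)c2)CCCC1` is the next compound to be tested. It differs from compound 2 in a single place: hydroxy in place of methylcarbamoyl on an aromatic carbon. Going by the values given here, no measured step touches this exact position, and the only step seen so far, from compound 1 to compound 2, concerns a different part of the molecule, so it bears on the new change only indirectly, by showing that the methylcarbamoyl-bearing ring gave the strongest number recorded.

On that basis compound 3 is expected to lose some of that advantage, with a step of a 13-fold higher number from compound 2 to compound 3 (1.10 log units; beyond the scatter) in this assay. The estimate for compound 3 is 10 nM, with a range from 2 nM to 60 nM.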

Compound 3, half-maximal inhibitory concentration in the histone acetyltransferase p300 assay: 0.631 nM
Compound 3: the middle estimate sits 16-fold (1.20 log units) above what was measured; the whole stated range lies above it.
By their numbers in the histone acetyltransferase p300 assay, from the lowest: compounds 3 and 2 (each within the scatter of the next); then compound 1.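

At the position para to a large group, the exchange of methylcarbamoyl for hydroxy gives, in the histone acetyltransferase p300 assay, a 1.3-fold lower number from compound 2 to compound 3 (0.10 log units; within the scatter), so the full methylcarbamoyl group is not required to keep the number in the range of compound 2. Both groups carry 1 hydrogen-bond donor and 1 hydrogen-bond acceptor, and the hydroxy-bearing ring also stands well clear of the group with the five-membered aromatic ring, with a 32-fold lower number from compound 1 to compound 3 (1.50 log units; beyond the scatter), a large step like the one seen with the methylcarbamoyl-bearing ring. In a physicochemical assay for lipophilicity, at pH 7.4 (on this read-out higher numbers stand for higher lipophilicity and lower numbers for lower lipophilicity), compound 2 gives 5.3 and compound 3 gives 5.5, and the same exchange reads a number 0.20 log units higher from compound 2 to compound 3 (within the scatter), so this read-out does not separate the two compounds either.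

The compounds shown leave open whether a methoxy group, an amine or a carboxylic acid at this place would also stay in this range. They also leave open how a hydrogen atom alone at this place would read, and so whether any group is needed there at all. Nothing shown here accounts for the close agreement between compound 2 and compound 3.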